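Trimming an Amide Substituent and Oral Exposure in Rat

A few compounds are considered here, and "the series" means these few. Any claim that something is new, unique, unknown or untested is made for them only; others in the source may bear on it.

Measured so far:
compound 1, `CC[C@@H](Nc1c(Nc2cccc(C(=O)N(C)C(C)C)c2O)c(=O)c1=O)c1ccccc1`: 590 ng.h/mL
compound 2, `CC[C@@H](Nc1c(Nc2ccc(Br)c(C(=O)N(C)C)c2O)c(=O)c1=O)c1ccccc1`: 28.3 ng.h/mL

In an ADME assay on the whole organism (plasma) for pharmacokinetics, with Rattus norvegicus as the target, at a dose of 10 mg/kg by the oral route (on this read-out lower numbers stand for lower exposure and higher numbers for higher exposure at the dose given), compound 1 holds the higher of the two numbers, and the nearest, compound 2 with 28.3 ng.h/mL, sits at a gap beyond the scatter. Compound 3, `CC[C@@H](Nc1c(Nc2cccc(C(=O)NC)c2O)c(=O)c1=O)c1ccccc1`, is not yet measured. It differs from compound 1 by hydrogen in place of isopropyl on an amide-type nitrogen. For the measured compounds named here, no measured pair shows this change, so its size is unknown; a modest downward step is expected, a 1.7-fold lower number from compound 1 to compound 3 (0.23 log units; within the scatter), though one within the scatter would not surprise. Compound 3 is thus expected to give 350 ng.h/mL, within 80 ng.h/mL to 1500 ng.h/mL.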

Compound 3, area under the concentration-time curve: 152 ng.h/mL
Compound 3: middle estimate off by 2.3-fold (0.36 log units), on the high side; the range from low to high includes it.
By their numbers in this assay, from the lowest: compound 2; then compound 3; then compound 1.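

The change from isopropyl to hydrogen on the amide-type nitrogen gives a 3.9-fold lower number from compound 1 to compound 3 (0.59 log units; beyond the scatter) in this assay and shows that this substituent matters for oral exposure in rat. Compound 2 could not show this, since it differs from compound 1 in more than one place. Nothing available here explains the size of the step.

As far as these compounds go, how an ethyl group or a cyclopropyl group on this nitrogen would compare remains open. So does whether a longer chain would restore the exposure of compound 1 or lower it further.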